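The compounds below may be only part of what the source reports. "The series", "measured", "known", "first", "only" and "open" are said of these compounds alone.

Compound 2 `COc1ccc(NC(=O)[C@H]2CC=C(CCC=C(C)C)C[C@@H]2c2ccccc2)cc1` carries an amide whose nitrogen bears a 4-methoxyphenyl group. In an assay on isolated protein for inhibition of Apoptosis regulator Bcl-2 (Homo sapiens), read by fluorescence polarization, with stated times of 5 min and 10 min (a higher number here means a weaker inhibitor, a lower number a stronger inhibitor), compound 2 gives only a limit of the assay, > 23000 nM. Its neighbour compound 1 `CC(C)=CCCC1=CC[C@H](C(=O)Nc2ccc(C(=O)O)cc2)[C@@H](c2ccccc2)C1` differs from it in a single group. In this assay compound 1 likewise gives only a limit, > 23000 nM. Going by the values given here, the one change between them, a step that the two limits leave unreadable from compound 1 to compound 2, therefore cannot be read, since (the limit of > 23000 nM in this assay, at which 2 of the 2 values shown sit). Compound 3 `CONC(=O)[C@H]1CC=C(CCC=C(C)C)C[C@@H]1c1ccccc1` is the unmeasured partner, and the change from compound 2 is methoxy in place of 4-methoxyphenyl on an amide-type nitrogen. No measured step bears on this change, and compound 2 itself stands only at a limit, so neither a direction nor a size of step can be drawn from the numbers shown. With both measured compounds at the limit, compound 3 is expected to remain beyond it as well, an expected step that the limit leaves unreadable from compound 2 to compound 3. The estimate for compound 3 is 40000 nM, within a range from 15000 nM to 150000 nM.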

Compound 3, inhibition constant: 2400 nM
The estimate for compound 3 lay 17-fold (1.22 log units) above the measured number, outside the stated range (below it).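

In this assay, the amide-type nitrogen proves to be a place where a change can be read: methoxy in place of 4-methoxyphenyl gives an at least 9.5-fold lower number from compound 2 to compound 3 (0.98 log units; beyond the scatter), and methoxy in place of 4-carboxyphenyl gives an at least 9.5-fold lower number from compound 1 to compound 3 (0.98 log units; beyond the scatter). Going by these compounds, the earlier pair could not show this, as swapping the group on the aromatic ring left both compounds out of range, and the true sizes of these steps also stay unknown: the limit of > 23000 nM in this assay, at which 2 of the 3 values shown sit. So among these three compounds, only the one without an aromatic ring on that nitrogen gives a readable number.

On these data alone, what stays open is whether the oxygen on that nitrogen matters or only the removal of the aromatic ring. A plain methyl, a hydroxyl or a longer ethoxy on the same nitrogen would separate these possibilities.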